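This account rests on a few compounds, and the source may have more. Where it says the series, first, only, none or still open, it means among the compounds named here.

Measured so far:
Compound 1 `COc1cc(CNCc2ccccc2)ccc1OCc1ccc(Cl)nc1`: 90000 nM
Compound 2 `COc1cc(CNCc2ccncc2)ccc1OCc1ccc(C)cc1`: 5000 nM

In a functional assay on HeLa cells (Homo sapiens) for inhibition, with a stated time of 72 h (a higher number here means that more compound is needed for the effect, a lower number that less compound is needed), only these two compounds have numbers. Compound 1 stands at the high end with 90000 nM, so more of it is needed for the effect. The nearest value belongs to compound 2, at 5000 nM, a lower number and a gap beyond the scatter. The two compounds differ in more than one place, so their gap says nothing about any single change.

Compound 3 `COCCNCc1ccc(OCc2ccc(Cl)nc2)c(OC)c1` keeps the core of compound 1 and alters one group: methoxymethyl in place of phenyl on a saturated chain carbon bound to an amine nitrogen. Methoxymethyl stands in place of phenyl on a saturated chain carbon bound to an amine nitrogen, which can also be read as benzyl to 2-methoxyethyl. Going by the values given here, no measured pair shows this change, so the expectation starts from compound 1 and its 90000 nM, with wide margins. The expected result is a 1.1-fold lower number from compound 1 to compound 3 (0.05 log units; within the scatter), a step in this assay that is not expected to go beyond the scatter. For compound 3 the estimated value is 80000 nM, with an expected range from 20000 nM to 250000 nM.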

Compound 3, half-maximal effective concentration: 97000 nM
For compound 3 the middle estimate is 1.2-fold (0.08 log units) below the measured one, and the stated range covers the measured number.
By their numbers in this assay, from the lowest: compound 2; then compounds 1 and 3 (each within the scatter of the next).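

In this assay, putting methoxymethyl in place of phenyl on a saturated chain carbon bound to an amine nitrogen gives a 1.1-fold higher number from compound 1 to compound 3 (0.03 log units; within the scatter), and this is the only step among the compounds shown that isolates a single change. In this one pair, a group of 6 heavy atoms with one six-membered aromatic ring of carbon only gives way to a group of 3 heavy atoms with no ring and 1 hydrogen-bond acceptor, and the number stays within the scatter, so at this position and on the core of compound 1 the assay does not separate the two groups. No available evidence explains this result.

Going by these compounds, whether a carboxylic acid, a further amine or a longer chain at this place would give a number beyond the scatter remains open, as does whether the same exchange would behave alike on another core. Going by these compounds alone, also open is which of the several differences from compound 1 goes with the lower number of compound 2, at 5000 nM, since no single-change step connects compound 2 to the others.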